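The compounds below may be only part of what the source reports. "The series", "measured", "known", "first", "only" and "open" are said of these compounds alone.

Of the compounds shown here, three of a shared core have been measured. Compound 1 `O=C(Nc1ccccc1)Nc1ccc(S(=O)(=O)Nc2ccnc3cc(C(F)(F)F)ccc23)cc1` was found "not active" (no number reported) in a functional assay on HepG2 cells (Homo sapiens) for antiproliferative activity, read by sulforhodamine B assay, with a stated time of 48 h; on this read-out higher numbers stand for weaker inhibition and lower numbers for stronger inhibition. Compound 2 `NS(=O)(=O)c1ccc(N/C(S)=N\c2ccnc3cc(C(F)(F)F)ccc23)cc1` gives 52200 nM in this assay, and compound 3 `N=C(N)NS(=O)(=O)c1ccc(N/C(S)=N\c2ccnc3cc(C(F)(F)F)ccc23)cc1` gives 33500 nM, the lowest of the two numbers reported, though the step of a 1.6-fold lower number from compound 2 to compound 3 (0.19 log units; within the scatter) stays within the scatter. Compound 4 `Cc1noc(NS(=O)(=O)c2ccc(N/C(S)=N\c3ccnc4cc(C(F)(F)F)ccc34)cc2)c1C` differs from compound 3 by a group of 7 heavy atoms (5 carbon, 1 nitrogen, 1 oxygen; one five-membered aromatic ring with 2 hetero atoms) in place of a group of 3 heavy atoms (1 carbon, 2 nitrogen; no ring), on a sulfonamide nitrogen. For the measured compounds named here, only the step from compound 2 to compound 3 touches the same sulfonamide nitrogen, and it was small; no measured step shows a ring entering at this place. For compound 4 a step of about a 1.3-fold lower number from compound 3 to compound 4 (0.13 log units; within the scatter) in this assay is therefore expected, not beyond the scatter. Compound 4 is estimated at 25000 nM, in a range from 7000 nM to 90000 nM.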

Compound 4, half-maximal inhibitory concentration: 36800 nM
Compound 4: the middle estimate sits 1.5-fold (0.17 log units) below what was measured; low and high end bracket the measured number.
By their numbers in this assay, from the lowest: compounds 3, 4 and 2 (each within the scatter of the next).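

For the compounds shown here, at the sulfonamide nitrogen a ring now enters for the first time, and in this assay the 3,4-dimethyl-1,2-oxazol-5-yl group stays within the scatter on both comparisons, with a 1.1-fold higher number from compound 3 to compound 4 (0.04 log units; within the scatter) and a 1.4-fold lower number from compound 2 to compound 4 (0.15 log units; within the scatter). This read-out therefore does not tell hydrogen, the group of compound 3 and this ring apart at this position, even though the groups differ considerably in size. Nothing available explains this flat result. On these data alone, whether a carboxylic acid, an amine or a longer chain on this nitrogen would move the number beyond the scatter remains open.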